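Working notes: replacing the six-membered aromatic ring

The source may hold more compounds than are shown below. What is called first, only, known or untested is meant among the compounds shown, and "the series" means these compounds.

In a physicochemical assay for lipophilicity, using the shake flask method, measured as octanol-water partition, at pH 7.4 (on this read-out higher numbers stand for higher lipophilicity and lower numbers for lower lipophilicity), compound 2 `CC(=O)N[C@@H]1CCC[C@H](C(=O)Nc2cc(-c3cnc4ccccn34)c(Cl)cn2)C1` stands highest at 3, while compound 1 `CC(=O)N[C@@H]1CCC[C@H](C(=O)Nc2cc(-c3cnn(C)c3C)c(Cl)cn2)C1` gives 2.6. Compound 3 `CC(=O)N[C@@H]1CCC[C@H](C(=O)Nc2cc(-c3cnn4c3CCC4)c(Cl)cn2)C1` has not yet been measured. Its structure differs from that of compound 2 as follows: a group of 8 heavy atoms (6 carbon, 2 nitrogen; one five-membered non-aromatic ring with 1 hetero atom, one five-membered aromatic ring with 2 hetero atoms) in place of a group of 9 heavy atoms (7 carbon, 2 nitrogen; one five-membered aromatic ring with 2 hetero atoms, one six-membered aromatic ring with 1 hetero atom), on an aromatic carbon. The six-membered aromatic ring leaves, while a five-membered aromatic ring with 2 hetero atoms remains, as in compound 1. The new group has a size between those of the two measured groups.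

For the measured compounds named here, only one measured step bears on this change: a number 0.40 log units higher from compound 1 to compound 2 (beyond the scatter). That step was modest, and the new change partly reverses it, so a small fall is expected in this assay, estimated as a number 0.30 log units lower from compound 2 to compound 3 (within the scatter). With a single step behind it, this expectation remains loose. For compound 3 the estimated value is 2.7, with an expected range of 2.3 to 3.1.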

Compound 3, distribution coefficient: 2.9
Beside the measured number, compound 3's estimate is 0.20 log units below it; measured number inside the range.
By their numbers in this assay, from the lowest: compounds 1, 3 and 2 (each within the scatter of the next, the first and the last beyond it).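

In this assay, the group with the five-membered non-aromatic ring gives two steps that both lie within the scatter (a number 0.10 log units lower from compound 2 to compound 3 (within the scatter)) and (a number 0.30 log units higher from compound 1 to compound 3 (within the scatter)), so compound 3 cannot be separated from either of the other two compounds. For the compounds shown here, at this position, the single step beyond the scatter now has a compound of intermediate group size that is not distinguishable from either end, and the loss of the six-membered aromatic ring gives no readable change on this read-out. Nothing available accounts for these small differences.

Open, going by these compounds, is whether a different group on this aromatic carbon, such as an amine or a carboxylic acid, would give a step beyond the scatter. Also open, on these data alone, is whether replacing the chloro group would alter the steps seen here.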